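A chlorine shifted along the benzyl arm

The source may report more compounds than this note shows. Statements on the series, on what has been measured and on what is new or still open speak of the compounds shown alone.

Compound 1 `COc1ccc(C2N=C(SCc3ccccc3Cl)NC(C)=C2C(=O)Nc2ccc(F)cc2)cc1OC` and compound 2 `COc1ccc(C2N=C(SCc3cccc(Cl)c3)NC(C)=C2C(=O)Nc2ccc(F)cc2)cc1OC` share one core and differ in a single place. In a functional assay on the whole organism (artery, strain albino) with Rattus norvegicus as the target, with a stated time of 360 min, at a dose of 10 mg/kg by the oral route (a lower number here means less inhibition, a higher number more inhibition at the dose given (going by the name of the read-out)), compound 1 gives 39.2%, while compound 2 gives 20.1%. The change between them is 3-chlorophenyl in place of 2-chlorophenyl on a saturated chain carbon bound to a sulfur and the step it made was a number 19.1 percentage points lower from compound 1 to compound 2 (beyond the scatter).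

Compound 3 `CC1=C(C(=O)Nc2ccc([N+](=O)[O-])cc2)C(c2ccc(Br)cc2)N=C(SCc2ccccc2Cl)N1` carries a different core, and the difference between the two cores is not broken down here. In this assay compound 3 gives 13.9%. Against compound 1 this number is beyond the scatter of the method, whereas against compound 2 the two values lie within that scatter, so no order between compound 2 and compound 3 can be read from them.

Compound 4 `CC1=C(C(=O)Nc2ccc([N+](=O)[O-])cc2)C(c2ccc(Br)cc2)N=C(SCc2cccc(Cl)c2)N1` has not yet been measured. It stands to compound 3 exactly as compound 2 stands to compound 1: the change is 3-chlorophenyl in place of 2-chlorophenyl on a saturated chain carbon bound to a sulfur, at the same place as before, so this is the same change made on a second core. Within the data shown here, only one measured example of the change exists, and the core of compound 3 already sits low, so a step of the earlier size cannot be taken over unchanged. Compound 4 is expected to move by a number 7.9 percentage points lower from compound 3 to compound 4 (within the scatter), a smaller step than the first, because the starting point of compound 3 is 13.9% and the read-out has little room left downward. The estimate for compound 4 in this assay is 6%, with a range from -6% to 18%.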

Compound 4, a percentage reported as inhibition, in the whole organism at one dose (the size of the read-out at that dose, not a potency): 7.2%
Compound 4: the middle estimate sits 1.2 percentage points below what was measured, within the range that was stated.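

In this assay, the change from 2-chlorobenzyl to 3-chlorobenzyl on the second core gave a number 6.7 percentage points lower from compound 3 to compound 4 (within the scatter), and set beside the first case, the two steps cannot be told apart in size: the same change on two cores in this assay, a number 19.1 percentage points lower (beyond the scatter) from compound 1 to compound 2 and a number 6.7 percentage points lower (within the scatter) from compound 3 to compound 4, 12.4 percentage points apart, within the scatter of two such steps What this shows is limited but useful: on both cores the number fell rather than rose, and the gap between the steps gives no sign that the core alters the effect of this change. It does not show that the change carries over as a step of fixed size, nor that it lowers the number on the second core at all, since that step on its own stays within the scatter and two pairs are a thin basis for any rule about the series.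

The compounds shown leave open how the sulfur arm behaves when the chlorine on the benzyl ring gives way to a nitrile or a trifluoromethyl group, or when the whole benzyl is replaced by a plain longer alkyl chain. They also leave open whether the same shift of the chlorine would follow this course on a third core, for instance one bearing a carboxylic acid or an amine on the ring of the amide.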